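The source may report more compounds than this note shows. Statements on the series, on what has been measured and on what is new or still open speak of the compounds shown alone.

Compound 1 `COC[C@]1(C(=O)N2CC[C@](c3ccc(C(F)(C(F)(F)F)C(F)(F)F)cc3)(S(=O)(=O)c3ccc(F)cc3)C2)CC[C@H](C(=O)O)CC1` is one of three related amides whose metabolic stability was followed in an ADME assay on microsomes from liver (Homo sapiens) for metabolic stability, with a stated time of 10 min; on this read-out lower numbers stand for a less stable compound and higher numbers for a more stable compound. In this assay compound 1 gives 100%, and it stands level, at the digits shown, with compound 3 `O=C(N1CC[C@](c2ccc(C(F)(C(F)(F)F)C(F)(F)F)cc2)(S(=O)(=O)c2ccc(F)cc2)C1)C1(F)CCS(=O)(=O)CC1`, which gives 100%. The third member, compound 2 `O=C(C1CCS(=O)(=O)C1)N1CC[C@](c2ccc(C(F)(C(F)(F)F)C(F)(F)F)cc2)(S(=O)(=O)c2ccc(F)cc2)C1`, gives 100%; 100% (2 entries). Within the data shown here, the one measured step that reaches compound 1 is no change at the digits printed from compound 1 to compound 3 (within the scatter), a change on the same carbonyl carbon that leaves the read-out unmoved within the scatter.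

Compound 4 `O=C(N1CC[C@](c2ccc(C(F)(C(F)(F)F)C(F)(F)F)cc2)(S(=O)(=O)c2ccc(F)cc2)C1)C1(O)CCS(=O)(=O)CC1` differs from compound 1 in the same place: 4-hydroxy-1,1-dioxothian-4-yl in place of 4-carboxy-1-(methoxymethyl)cyclohexyl on a carbonyl carbon. The step from compound 1 to compound 3, which exchanges the same group for a close relative of the group entering in compound 4, gave no change, so no movement beyond the scatter is expected here either, in either direction; compound 4 is estimated at 98%, between 85% and 100%, which as a step means a number 2 percentage points lower from compound 1 to compound 4 (within the scatter).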

Compound 4, percent of the compound remaining: 100%
Beside the measured number, compound 4's estimate is 2 percentage points below it, within the range that was stated.
By their numbers in this assay, from the lowest: compounds 1, 3 and 4 (each within the scatter of the next).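

With compound 4, the exchange on the carbonyl carbon no longer rests on a single entering group: 4-hydroxy-1,1-dioxothian-4-yl in place of 4-carboxy-1-(methoxymethyl)cyclohexyl gives no change at the digits printed from compound 1 to compound 4 (within the scatter) in this assay. The saturated ring carbon of the entering group can now be read as well, and hydroxy in place of fluoro there gives no change at the digits printed from compound 3 to compound 4 (within the scatter). No measurement bears on why the read-out stays unmoved in these steps.

All the compounds shown stand at one printed level, so they do not show which change at either place would lower the read-out. On these data alone, whether an amine or a longer chain in place of hydroxy on the saturated ring carbon would move the number remains open.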